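Moving a fluorine around the benzyl ring

The compounds below may be only part of what the source reports. "The series", "measured", "known", "first", "only" and "open" are said of these compounds alone.

Three compounds share one core and differ only in the group on the ring nitrogen. Compound 1 `CC1(C)c2[nH]nc(NC(=O)c3ccccc3)c2CN1Cc1ccccc1` carries a plain benzyl group and in an assay on Sf21 cells for inhibition of high affinity nerve growth factor receptor (Homo sapiens), read by HTRF, with a stated time of 30 min, in the presence of a further agent that is not named here (a lower number here means a stronger inhibitor, a higher number a weaker inhibitor), compound 1 gives 1240 nM. Compound 2 `CC1(C)c2[nH]nc(NC(=O)c3ccccc3)c2CN1Cc1cccc(Cl)c1` gives 670 nM, and compound 3 `CC1(C)c2[nH]nc(NC(=O)c3ccccc3)c2CN1Cc1ccccc1F` gives 450 nM. The change a 1.9-fold lower number from compound 1 to compound 2 (0.27 log units; within the scatter) lies within the scatter, whereas a 2.8-fold lower number from compound 1 to compound 3 (0.44 log units; beyond the scatter) is a modest change beyond it; the gap a 1.5-fold lower number from compound 2 to compound 3 (0.17 log units; within the scatter) is within the scatter, so compound 3 and compound 2 cannot be told apart, while compound 3 sits clearly apart from compound 1.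

Compound 4 `CC1(C)c2[nH]nc(NC(=O)c3ccccc3)c2CN1Cc1ccc(F)cc1` is made from compound 3 by 4-fluorophenyl in place of 2-fluorophenyl on a saturated chain carbon bound to an amine nitrogen in a ring. Among the compounds with values here, no measured step moves a fluorine from one place on this ring to another; the only relevant steps add a halogen to the unsubstituted ring, and those were small. The expectation is therefore a 1.3-fold higher number from compound 3 to compound 4 (0.12 log units; within the scatter), a step that stays within the scatter. Compound 4 is expected to give about 600 nM in this assay, with a range from 250 nM to 1500 nM.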

Compound 4, half-maximal inhibitory concentration: 1180 nM
For compound 4 the middle estimate is 2.0-fold (0.29 log units) below the measured one; measured number inside the range.
By their numbers in this assay, from the lowest: compounds 3, 2, 4 and 1 (each within the scatter of the next, the first and the last beyond it).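

Where the fluorine sits on the ring matters: the two compounds have the same atoms, yet going from 2-fluorobenzyl to 4-fluorobenzyl gives a step beyond the scatter (a 2.6-fold higher number from compound 3 to compound 4 (0.42 log units; beyond the scatter)), which the earlier compounds, with no two sharing a halogen, could not show. The 4-fluorophenyl group gives no readable gain over the plain phenyl ring (a 1.1-fold lower number from compound 1 to compound 4 (0.02 log units; within the scatter)), and it cannot be told apart from 3-chlorophenyl (a 1.8-fold higher number from compound 2 to compound 4 (0.25 log units; within the scatter)). Nothing measured here explains the difference between the two fluorine placements.

From the compounds shown here alone, it remains open whether a methoxy group or a nitrile in place of the fluorine on 2-fluorophenyl would keep the number of compound 3. Going by these compounds, it is also open whether the step from 2-fluorophenyl to 4-fluorophenyl would repeat on another core.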